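Chain methylation carried from one core to another

The source may hold more compounds than are shown below. What is called first, only, known or untested is meant among the compounds shown, and "the series" means these compounds.

Compound 1 `CC/C=C\C(=O)Nc1cc(Nc2ncc(C#N)c(-c3cn(C)c4ccccc34)n2)c(OC)cc1N(C)CCN(C)C` gives 1360 nM in a functional assay on HepG2 cells (Homo sapiens) for antiproliferative activity, read by MTT assay, with a stated time of 72 h; a higher number here means a weaker inhibitor, a lower number a stronger inhibitor. Compound 2 `CCC/C=C\C(=O)Nc1cc(Nc2ncc(C#N)c(-c3cn(C)c4ccccc34)n2)c(OC)cc1N(C)CCN(C)C` carries methyl in place of hydrogen on a saturated chain carbon, two bonds along the chain from a double-bonded chain carbon and in this assay compound 2 gives 1690 nM; the step is a 1.2-fold higher number from compound 1 to compound 2 (0.09 log units; within the scatter). Compound 3 `CC/C=C\C(=O)Nc1cc(Nc2nc(C)cc(-c3cn(C)c4ccc(F)cc34)n2)c(OC)cc1N(C)CCN(C)C` is built on a different core, and the difference between the two cores is not broken down here. In this assay compound 3 gives 11000 nM, the highest number of the three, with both of the other values lying beyond the scatter below it.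

Compound 4 `COc1cc(N(C)CCN(C)C)c(NC(=O)/C=C\C(C)C)cc1Nc1nc(C)cc(-c2cn(C)c3ccc(F)cc23)n1` is not yet measured and carries methyl in place of hydrogen on a saturated chain carbon bound to a double-bonded chain carbon and a saturated chain carbon. Within the data shown here, this is the same kind of change as the one from compound 1 to compound 2, but not the same: there the methyl entered two bonds along the chain from a double-bonded chain carbon, here it enters on a saturated chain carbon bound to a double-bonded chain carbon and a saturated chain carbon. A step of a 1.1-fold higher number from compound 3 to compound 4 (0.04 log units; within the scatter) is expected, close to the earlier one, because a 1.2-fold higher number from compound 1 to compound 2 (0.09 log units; within the scatter) stayed within the scatter. For compound 4 a value of 12000 nM is estimated, with a range from 6000 nM to 25000 nM.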

Compound 4, half-maximal inhibitory concentration: 14000 nM
Compound 4: middle estimate off by 1.2-fold (0.07 log units), on the low side; the range from low to high includes it.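

In this assay, methyl on a saturated chain carbon bound to a double-bonded chain carbon and a saturated chain carbon gives a 1.3-fold higher number from compound 3 to compound 4 (0.10 log units; within the scatter), and this step agrees with the one seen on the other core: the same change on two cores in this assay, a 1.2-fold higher number (0.09 log units; within the scatter) from compound 1 to compound 2 and a 1.3-fold higher number (0.10 log units; within the scatter) from compound 3 to compound 4, 1.0-fold (0.01 log units) apart, within the scatter of two such steps

On these two pairs, then, adding one methyl to the chain leaves the antiproliferative read-out within the scatter on either core, so the result carries over from the core of compound 1 to the core of compound 3. Among these compounds, it does not show that the two changes are equivalent, as the methyl enters at a different chain carbon in each pair, and with only two pairs in one cell assay it sets no rule for other cores or other chain changes.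

Still open, as far as these compounds go, is whether larger changes on the same chain, such as a longer chain, a phenyl ring or a terminal amine, would also leave the read-out within the scatter. The difference between the two cores also remains unresolved, as no pair shown separates its parts.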